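The source may report more compounds than this note shows. Statements on the series, on what has been measured and on what is new or still open speak of the compounds shown alone.

Measured so far in a functional assay on ACHN cells (Homo sapiens) for cytotoxicity, read by sulforhodamine B assay, with a stated time of 72 h; on this read-out higher numbers stand for weaker inhibition of growth and lower numbers for stronger inhibition of growth:
- compound 1, `CC(=O)N1c2ccccc2CCC1C(=O)Nc1ccccc1O`: 50700 nM
- compound 2, `O=C(Nc1ccc(C(F)(F)F)cc1)C1CCc2ccccc2N1`: 25000 nM
- compound 3, `CC(=O)N1c2ccccc2CCC1C(=O)Nc1cc(C(F)(F)F)cc(C(F)(F)F)c1`: > 70000 nM

Of the two numbers, compound 1 stands highest in this assay. Compound 2 sits at a lower number, a step that lies beyond the usual scatter. For compound 3 this assay reports only a limit, > 70000 nM, not a number.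

The next compound, compound 4, `CCCCCCCCC(=O)N1c2ccccc2CCC1C(=O)Nc1ccccc1O`, differs from compound 1 in one place: heptyl in place of hydrogen on a saturated chain carbon bound to a carbonyl carbon. For the measured compounds named here, no comparable step has been measured, so the direction rests on expectation alone. A modest step toward a lower number is expected, a 1.7-fold lower number from compound 1 to compound 4 (0.23 log units; within the scatter), though one not far beyond the scatter. Compound 4 is therefore estimated at 30000 nM, within 8000 nM to 70000 nM.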

Compound 4, concentration for 50% growth inhibition: 65000 nM
The estimate for compound 4 lay 2.2-fold (0.34 log units) below the measured number; low and high end bracket the measured number.
By their numbers in this assay, from the lowest: compound 2; then compounds 1 and 4 (each within the scatter of the next). At a limit, above all of these: compound 3.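

In this assay, heptyl in place of hydrogen on a saturated chain carbon bound to a carbonyl carbon gives a 1.3-fold higher number from compound 1 to compound 4 (0.11 log units; within the scatter), so this long chain brings no measurable gain in growth inhibition over the acetyl of compound 1. The position accepts the change without a readable shift in either direction. Compound 3 gives only a limit, and little measurable range may remain for still weaker compounds: the limit of > 70000 nM in this assay, at which 1 of the 4 values shown sits.

On these data alone, whether an amine or a carboxylic acid at this position would move the number stays open. So does whether a chain of intermediate length would behave like methyl and heptyl.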